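Adding a Chloro to the Benzyl of Compound 1

The compounds below may be only part of what the source reports. "The series", "measured", "known", "first", "only" and "open" are said of these compounds alone.

Among the measured compounds shown here, in a functional assay on RS4-11 cells (Homo sapiens) for inhibition, read by CCK-8 assay, with a stated time of 48 h, tested at 20 uM (a higher number here means more inhibition of growth at the concentration tested, a lower number less inhibition of growth), compound 1 (`N#C/C(=C\c1ccccc1OS(=O)(=O)c1ccc([N+](=O)[O-])cc1)C(=O)Nc1nnc(Cc2ccccc2)s1`) gives 57%, the lowest of the three numbers so far. Compound 2 (`N#C/C(=C\c1ccccc1OS(=O)(=O)c1ccccc1[N+](=O)[O-])C(=O)Nc1nnc(Cc2ccccc2)s1`) gives 71%, and compound 3 (`N#C/C(=C\c1ccccc1OS(=O)(=O)c1ccc(Cl)cc1)C(=O)Nc1nnc(Cc2ccccc2)s1`) gives 73%. Compound 4 (`N#C/C(=C\c1ccccc1OS(=O)(=O)c1ccc([N+](=O)[O-])cc1)C(=O)Nc1nnc(Cc2ccc(Cl)cc2)s1`) keeps the 4-nitrophenyl group of compound 1 and turns benzyl into 4-chlorobenzyl: chloro in place of hydrogen on an aromatic carbon. For the measured compounds named here, no measured step touches the benzyl, so the evidence is indirect. Both measured steps away from compound 1, a number 14 percentage points higher from compound 1 to compound 2 (beyond the scatter) and a number 16 percentage points higher from compound 1 to compound 3 (beyond the scatter), change the group on the sulfonyl sulfur. The second also brings in a chloro on an aromatic carbon, but there it replaces nitro, which makes it only a loose guide. A modest rise in this assay therefore seems more likely than a fall, though it may stay within the scatter. The expected change is a number 7 percentage points higher from compound 1 to compound 4 (within the scatter). Compound 4 is estimated to give 64%, with an expected range of 50% to 78%.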

Compound 4, percent growth inhibition at one concentration: 66%
The estimate for compound 4 lay 2 percentage points below the measured number; low and high end bracket the measured number.
By their numbers in this assay, from the lowest: compounds 1, 4, 2 and 3 (each within the scatter of the next, the first and the last beyond it).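

In this assay, among the compounds shown here, the first change at the benzyl, chloro in place of hydrogen on an aromatic carbon, gives a number 9 percentage points higher from compound 1 to compound 4 (within the scatter), so this single chloro on the benzyl of compound 1 cannot be told from the scatter. For the compounds shown here, the only steps from compound 1 that lie beyond the scatter remain the two on the sulfonyl sulfur, a number 14 percentage points higher from compound 1 to compound 2 (beyond the scatter) and a number 16 percentage points higher from compound 1 to compound 3 (beyond the scatter). Nothing available gives a reason for the size of the step at the benzyl.

The compounds shown leave open whether a methoxy, an amine or a carboxylic acid in place of the chloro would read differently at this position. They also leave open whether the same chloro would give a similar step with the 2-nitrophenyl of compound 2 or the 4-chlorophenyl of compound 3 on the sulfonyl sulfur.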